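Replacing ethoxycarbonyl with hydroxymethyl in a small series

The source may hold more compounds than are shown below. What is called first, only, known or untested is meant among the compounds shown, and "the series" means these compounds.

Measured in a functional assay on Rec1 cells (Homo sapiens) for inhibition, read by luminescence and CellTiter-Glo, with a stated time of 72 h; a lower number here means a stronger inhibitor, a higher number a weaker inhibitor
compound 1 `CCOC(=O)c1cc(-c2ccc(Oc3ccccc3)cc2)nn1Cc1cccc(NC(=O)CCl)c1` gives 400 nM
compound 2 `C/C=C/C(=O)Nc1cccc(Cn2nc(-c3ccc(Oc4ccccc4)cc3)cc2CO)c1` gives 3400 nM
compound 3 `C=CC(=O)Nc1cccc(Cn2nc(-c3ccc(Oc4ccccc4)cc3)cc2C(=O)OCC)c1` gives 3300 nM

Compound 3 (3300 nM) lies within the scatter of compound 2 (3400 nM), and both numbers are higher than that of compound 1 (400 nM). The next structure is compound 4 `C=CC(=O)Nc1cccc(Cn2nc(-c3ccc(Oc4ccccc4)cc3)cc2CO)c1` where hydroxymethyl takes the place of ethoxycarbonyl on an aromatic carbon of a five-membered aromatic ring with 2 nitrogen (hydroxymethyl in place of ethoxycarbonyl on an aromatic carbon). The group on the carbonyl carbon stays as in compound 3.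

For the measured compounds named here, the one measured step is an 8.3-fold higher number from compound 1 to compound 3 (0.92 log units; beyond the scatter) and it concerns the group on the carbonyl carbon, not the site changing here. It therefore gives no direct measure of this replacement. The nearest evidence is compound 2 (3400 nM), which already carries hydroxymethyl but has a different group on that carbonyl carbon, and its number sits within the scatter of the number for compound 3. In this assay the expected step is a 1.3-fold lower number from compound 3 to compound 4 (0.12 log units; within the scatter) and no shift beyond the scatter is anticipated. For compound 4 the estimated value is 2500 nM with a wide expected range (800 nM to 8000 nM).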

Compound 4, half-maximal inhibitory concentration: 1300 nM
Compound 4: middle estimate off by 1.9-fold (0.28 log units), on the high side, and the stated range covers the measured number.
By their numbers in this assay, from the lowest: compound 1; then compound 4; then compounds 3 and 2 (each within the scatter of the next).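

Site notes: in this assay, the replacement on the aromatic carbon of the five-membered aromatic ring with 2 nitrogen now has a direct reading with vinyl held constant on the carbonyl carbon: a 2.5-fold lower number from compound 3 to compound 4 (0.40 log units; beyond the scatter). For the compounds shown here, this shows that the site next to the ring nitrogen responds when ethoxycarbonyl gives way to hydroxymethyl, a change that the earlier compounds could not isolate. With hydroxymethyl held constant, vinyl in place of prop-1-en-1-yl on the carbonyl carbon gives a 2.6-fold lower number from compound 2 to compound 4 (0.42 log units; beyond the scatter), so the group on the carbonyl carbon also moves the number in this hydroxymethyl setting. No supporting data are available to explain either step.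

On these data alone, it remains open whether hydroxymethyl in place of ethoxycarbonyl gives a step of similar direction and size when chloromethyl sits on the carbonyl carbon, as it does in compound 1 (400 nM). The compounds shown also leave open how a carboxylic acid, an aminomethyl group or a longer chain such as 2-hydroxyethyl would read on this aromatic carbon.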